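The compounds below may be only part of what the source reports. "The series", "measured", "known", "first", "only" and "open" are said of these compounds alone.

In an ADME assay on CHO cells (Cricetulus griseus) for cytotoxicity, read by LDH release (a higher number here means a weaker inhibitor, a lower number a stronger inhibitor), compound 1 (`CC(Oc1ccc(Cl)cc1Cl)C(=O)NNCc1ccc(F)cc1`) gives 31000 nM, compound 2 (`CC(Oc1ccc(Cl)cc1Cl)C(=O)NCc1cccc(F)c1`) gives 27000 nM and compound 3 (`CC(Oc1ccc(Cl)cc1Cl)C(=O)NCc1ccc(Cl)cc1`) gives 39000 nM, so compound 3 stands within the scatter of both others. Compound 4 (`Cc1ccc(CNC(=O)C(C)Oc2ccc(Cl)cc2Cl)cc1`) has not been measured. It carries methyl in place of chloro on an aromatic carbon, para to a large group: methyl in place of chloro on an aromatic carbon. Among the compounds with values here, the only measured step that touches this aryl group is a 1.4-fold higher number from compound 2 to compound 3 (0.16 log units; within the scatter), and no other measured step bears on the change. No step beyond the scatter is therefore expected in this assay. The expected step is a 1.0-fold lower number from compound 3 to compound 4 (0.01 log units; within the scatter). Compound 4 is estimated at 38000 nM, with an expected range of 20000 nM to 75000 nM.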

Compound 4, half-maximal inhibitory concentration: 25000 nM
Beside the measured number, compound 4's estimate is 1.5-fold (0.18 log units) above it; low and high end bracket the measured number.
By their numbers in this assay, from the lowest: compounds 4, 2, 1 and 3 (each within the scatter of the next).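

In this assay, methyl and chloro on an aromatic carbon, para to a large group, are not told apart (a 1.6-fold lower number from compound 3 to compound 4 (0.19 log units; within the scatter)). The 4-methylphenyl and 3-fluorophenyl groups are also not told apart (a 1.1-fold lower number from compound 2 to compound 4 (0.03 log units; within the scatter)), so compounds 2, 3 and 4 all lie within the scatter of one another. Nothing measured here accounts for these small steps.

Going by these compounds, whether an amine or a carboxylic acid on this aromatic carbon would give a step beyond the scatter remains open. So does the effect of a longer chain at the same place.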